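The source may report more compounds than this note shows. Statements on the series, on what has been measured and on what is new or still open speak of the compounds shown alone.

Working notes on the series in a physicochemical assay for solubility; on this read-out higher numbers stand for higher solubility and lower numbers for lower solubility. Compound 1 `CC(C)[C@@H](N)C(=O)OC[C@H]1O[C@@H](n2cnc3c(N)ncnc32)[C@@H](O)[C@@H]1O` reads > 10000 ug/mL, which is a limit and not a number. Compound 2 `CC(C)C[C@@H](N)C(=O)OC[C@H]1O[C@@H](n2cnc3c(N)ncnc32)[C@@H](O)[C@@H]1O` reads > 10000 ug/mL, again a limit. Compound 3 `Nc1ncnc2c1ncn2[C@@H]1O[C@H](COC(=O)[C@H](N)CC(=O)O)[C@@H](O)[C@@H]1O` reads > 10000 ug/mL, also a limit, so its place in the series is known only as a limit. The set as a whole shows (the limit of > 10000 ug/mL in this assay, at which 3 of the 3 values shown sit).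

Compound 4 `Nc1ncnc2c1ncn2[C@@H]1O[C@H](COC(=O)C[C@@H](N)C(=O)O)[C@@H](O)[C@@H]1O` keeps the atoms of compound 3, joined differently: 2-amino-2-carboxyethyl in place of 1-amino-2-carboxyethyl on a carbonyl carbon. In words, 2-amino-2-carboxyethyl stands in place of 1-amino-2-carboxyethyl on a carbonyl carbon.

For the measured compounds named here, three measured steps bear on this change, all of them in the same side chain: a step that the two limits leave unreadable from compound 1 to compound 2, a step that the two limits leave unreadable from compound 1 to compound 3 and a step that the two limits leave unreadable from compound 2 to compound 3. None of them has a readable size, and none gives a direction. The expectation therefore rests on compound 3 with its limit of > 10000 ug/mL, and on the fact that every substituent tried so far gave the same reading. No step beyond the scatter is expected in this assay, and no direction is favoured. The expected size is a step that the limit leaves unreadable from compound 3 to compound 4. For compound 4 the estimated value is 12000 ug/mL, with an expected range of 5000 ug/mL to 30000 ug/mL.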

Compound 4, solubility: > 10000 ug/mL
Compound 4 gave a limit, no number; the forecaster's own chance of this, stated with the estimate: 85%; the middle value lies beyond the limit too.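

In this assay no new step can be read for compound 4, which gives only a limit, as do compound 1, compound 2 and compound 3, so all its comparisons with them remain unreadable. The series shows one feature: the limit of > 10000 ug/mL in this assay, at which 4 of the 4 values shown sit. The compounds shown leave open how these four compounds would rank if their values could be read as numbers.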